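Three Measured Compounds and One Open Question

A few compounds are considered here, and "the series" means these few. Any claim that something is new, unique, unknown or untested is made for them only; others in the source may bear on it.

Of the compounds shown here, three built on a shared core have been tested in a functional assay on A549 cells (Homo sapiens) for inhibition; on this read-out lower numbers stand for stronger inhibition of growth and higher numbers for weaker inhibition of growth. Compound 1 `COc1cc(/C=C/C(=O)c2cccc(-n3cc(-c4ccc(Cl)cc4)[nH]c3=O)c2)ccc1O` gives 6780 nM in this assay. Compound 2 `COc1cc(/C=C/C(=O)c2cccc(-n3cc(-c4ccccc4)[nH]c3=O)c2)cc(OC)c1OC` gives 4030 nM in this assay, and compound 3 `O=C(/C=C/c1cccc(O)c1)c1cccc(-n2cc(-c3ccccc3)[nH]c2=O)c1` gives 3890 nM in this assay. Among these three numbers compound 2 stands second highest; its nearest neighbour is compound 3 and its furthest is compound 1, yet both gaps fall within the usual scatter, so the three compounds cannot be told apart on these data.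

Compound 4 `COc1cc(/C=C/C(=O)c2cccc(-n3cc(-c4cc(OC)c(OC)c(OC)c4)[nH]c3=O)c2)cc(OC)c1OC` has not yet been measured in this assay. It differs from compound 2 in a single place: 3,4,5-trimethoxyphenyl in place of phenyl on an aromatic carbon. For the measured compounds named here, no pair of measured compounds differs in just one place, so there is no measured step to lean on, and nothing here shows how this particular change behaves.

The expectation therefore rests on the narrow spread seen so far. The expected step is a 1.6-fold lower number from compound 2 to compound 4 (0.21 log units; within the scatter), modest and leaning slightly toward stronger inhibition of growth, though not confidently beyond the scatter. For compound 4 the estimate in this assay is 2500 nM, with a range from 800 nM to 8000 nM.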

Compound 4, concentration for 50% growth inhibition: 3030 nM
Compound 4: the middle estimate sits 1.2-fold (0.08 log units) below what was measured, within the range that was stated.
By their numbers in this assay, from the lowest: compounds 4, 3, 2 and 1 (each within the scatter of the next, the first and the last beyond it).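

In this assay, for the compounds shown here, putting 3,4,5-trimethoxyphenyl in place of phenyl on an aromatic carbon of the five-membered ring gives a 1.3-fold lower number from compound 2 to compound 4 (0.12 log units; within the scatter), the first measured step that changes only one place on this scaffold. At this position, then, a clearly larger group, one that also brings hydrogen-bond acceptors absent from phenyl, leaves the read-out indistinguishable from that of the plain phenyl compound, although this rests on a single pair in a single cell assay. Nothing available here explains why the two compounds read alike.

On these data alone, it remains open whether an amine or a carboxylic acid on this phenyl ring, or a saturated ring such as cyclohexyl in its place, would shift the number beyond the scatter, so the limits of what this position accepts are still unknown. Also unsettled is whether the same exchange would read the same way with the other group of the chalcone-like arm changed, for example with the hydroxyphenyl that compound 3 carries there.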